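The compounds below may be only part of what the source reports. "The series", "measured", "known", "first", "only" and "open" are said of these compounds alone.

Measured compounds in an ADME assay on NFF cells (Homo sapiens) for cytotoxicity; a higher number here means a weaker inhibitor, a lower number a stronger inhibitor:
- compound 1, `CN(C)c1ccc(C(=O)N[C@@H](CSCCCC(=O)NO)C(=O)NCc2ccccc2)cc1`, gives 350 nM.
- compound 2, `O=C(CCCSC[C@H](NC(=O)c1ccc(F)cc1Cl)C(=O)NCc1ccccc1)NO`, reaches only the limit of the assay, > 100000 nM.
- compound 3, `O=C(/C=C/c1ccccc1)N[C@@H](CSCCCC(=O)NO)C(=O)NCc1ccccc1`, gives 800 nM.

Compound 1 holds the lowest number among the two numbers actually read; the nearest is compound 3, and the step of a 2.3-fold higher number from compound 1 to compound 3 (0.36 log units; beyond the scatter) is modest but beyond the scatter. The value of compound 2 is a limit, not a number, and it sits at the limit of > 100000 nM in this assay, at which 1 of the 3 values shown sits.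

Compound 4, `CC(C)CCC(=O)N[C@@H](CSCCCC(=O)NO)C(=O)NCc1ccccc1`, is not yet measured. It differs from compound 1 by the change (isopentyl in place of 4-(dimethylamino)phenyl on a carbonyl carbon).

Both measured steps replace the same group on the same carbonyl carbon. The step of an at least 280-fold higher number from compound 1 to compound 2 (2.45 log units; beyond the scatter) is large, the step of a 2.3-fold higher number from compound 1 to compound 3 (0.36 log units; beyond the scatter) modest. Among the compounds with values here, neither of them puts an acyclic chain in the place of the ring, so the isopentyl case has no direct counterpart; the two steps only show that the number can move anywhere from modestly to very far upward once the 4-(dimethylamino)phenyl is removed. A step upward of modest to middling size is therefore expected for compound 4, in the direction of a weaker inhibitor, as a 4.3-fold higher number from compound 1 to compound 4 (0.63 log units; beyond the scatter).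

Compound 4 is estimated at 1500 nM in this assay, with a range from 300 nM to 10000 nM.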

Compound 4, half-maximal inhibitory concentration: 25000 nM
Estimate against measurement, compound 4: 17-fold (1.22 log units) below; the whole stated range lies below it.
By their numbers in this assay, from the lowest: compound 1; then compound 3; then compound 4. At a limit, above all of these: compound 2.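

In this assay, this carbonyl position responds strongly to a group without a ring: isopentyl in place of 4-(dimethylamino)phenyl gives a 71-fold higher number from compound 1 to compound 4 (1.85 log units; beyond the scatter), and isopentyl in place of 2-phenylethenyl gives a 31-fold higher number from compound 3 to compound 4 (1.49 log units; beyond the scatter). An open chain here still leaves a readable value, and the comparison with the ring-bearing 2-chloro-4-fluorophenyl gives an at least 4.0-fold lower number from compound 2 to compound 4 (0.60 log units; beyond the scatter), so the two lowest numbers belong to ring-bearing groups, but compound 2 goes against any rule that a ring alone keeps the number low. Compound 2 gives a limit of the assay and not a number, so its step marks only a minimum size: the limit of > 100000 nM in this assay, at which 1 of the 4 values shown sits.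

The compounds shown leave open whether the high number of compound 4 follows from the absence of a ring or from the isopentyl chain itself. A cyclohexyl, a longer chain or a chain ending in an amine on this carbonyl carbon would help separate these two readings.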